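The compounds below may be only part of what the source reports. "The series", "measured", "known", "first", "only" and "open" are said of these compounds alone.

Of the compounds shown here, two built on the same core have so far been measured in a functional assay on OVCAR-4 cells (Homo sapiens) for cytotoxicity, read by sulforhodamine B assay, with a stated time of 48 h; on this read-out higher numbers stand for weaker inhibition of growth and lower numbers for stronger inhibition of growth. Compound 1 `Nc1nc(Cl)c2ncn(Cc3ccccc3CCl)c2n1` gives 6460 nM in this assay. Compound 2 `ClCc1ccc(Cn2cnc3c(Cl)nc(Cl)nc32)cc1` gives 18600 nM in this assay. Compound 1 therefore holds the lowest of the two numbers, and the gap separating it from compound 2 lies beyond the usual scatter, so compound 1 is the stronger growth inhibitor of the pair.

Compound 3 `ClCc1ccccc1Cn1cnc2c(Cl)ncnc21` has not yet been measured in this assay. It differs from compound 1 in a single place: hydrogen in place of amino on an aromatic carbon. For the measured compounds named here, no measured pair in this set shows a step of exactly this kind, so the direction and size of the step cannot be read from a precedent; the only measured comparison, between compound 1 and compound 2, involves other changes and offers no direct guide.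

Compound 3 is nevertheless expected to give a somewhat higher number than compound 1, with an estimated step of a 1.7-fold higher number from compound 1 to compound 3 (0.23 log units; within the scatter), a shift close to the edge of the scatter. Compound 3 is accordingly estimated at 11000 nM, with a range from 4000 nM to 30000 nM.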

Compound 3, concentration for total growth inhibition: 12300 nM
Compound 3: middle estimate off by 1.1-fold (0.05 log units), on the low side, and the stated range covers the measured number.
By their numbers in this assay, from the lowest: compounds 1, 3 and 2 (each within the scatter of the next, the first and the last beyond it).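

In this assay, for the compounds shown here, hydrogen in place of amino on an aromatic carbon, between two ring nitrogen atoms of the shared core, gives a 1.9-fold higher number from compound 1 to compound 3 (0.28 log units; within the scatter) and so provides the first measured step at this position. The earlier pair could not show this, since compound 1 and compound 2 differ in more than one place. The amino group can be absent here without a shift beyond the scatter, so within this pair the growth inhibition seen on this read-out does not depend on that group. Nothing available explains why this position accepts the change.

From the compounds shown here alone, a single step at a single position sets no trend, and it remains open whether a methylamino group, a methoxy group or a longer chain on the same aromatic carbon would also stay within the scatter of compound 1. Going by these compounds, it also remains open whether the same exchange of amino for hydrogen would read the same way on a core carrying a different group in place of the chloro group.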